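Amide nitrogen substituent series: tert-butyl to cyclohexyl

The source may hold more compounds than are shown below. What is called first, only, known or untested is meant among the compounds shown, and "the series" means these compounds.

Compound 1 `C=CC1=C(C(=O)NCCC)C(c2ccc(F)cc2)OC1`, compound 2 `C=CC1=C(C(=O)NCC(C)C)C(c2ccc(F)cc2)OC1` and compound 3 `C=CC1=C(C(=O)NC(C)(C)C)C(c2ccc(F)cc2)OC1` share one core and differ only in the group on the amide-type nitrogen. In a functional assay on QGY7701 cells (Homo sapiens) for cytotoxicity, read by MTT assay, with a stated time of 24 h (on this read-out higher numbers stand for weaker inhibition and lower numbers for stronger inhibition), compound 1 reaches only a limit, > 100000 nM. Compound 2 likewise gives a limit in this assay, > 100000 nM. Compound 3 also stops at a limit in this assay, > 100000 nM. The steps a step that the two limits leave unreadable from compound 1 to compound 2, a step that the two limits leave unreadable from compound 1 to compound 3 and a step that the two limits leave unreadable from compound 2 to compound 3 carry no readable size, since all values sit at the limit of > 100000 nM in this assay, at which 3 of the 3 values shown sit. Compound 4 `C=CC1=C(C(=O)NC2CCCCC2)C(c2ccc(F)cc2)OC1` carries the change (cyclohexyl in place of tert-butyl on an amide-type nitrogen). Within the data shown here, no measured step gives a readable size for this change. Compound 4 is expected to remain near the limit, with an estimated step that the limit leaves unreadable from compound 3 to compound 4. The estimate for compound 4 in this assay is 150000 nM, between 40000 nM and 600000 nM.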

Compound 4, half-maximal inhibitory concentration: 40500 nM
Compound 4: middle estimate off by 3.7-fold (0.57 log units), on the high side; measured number inside the range.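

In this assay, cyclohexyl gives the first readable result at this amide-type nitrogen: an at least 2.4-fold lower number from compound 3 to compound 4 (0.39 log units; beyond the scatter), an at least 2.4-fold lower number from compound 2 to compound 4 (0.39 log units; beyond the scatter) and an at least 2.4-fold lower number from compound 1 to compound 4 (0.39 log units; beyond the scatter). Among the groups shown, only the ring-bearing group leaves the limit, while propyl, isobutyl and tert-butyl stay there. Each step is only a lower bound because its starting compound has no exact value: the limit of > 100000 nM in this assay, at which 3 of the 4 values shown sit.

From the compounds shown here alone, the true sizes of these steps remain open. Going by these compounds, it is also open whether the ring or the size of the group drives the change, which an open hexyl chain or a cyclopentyl group could help separate.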